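The source may report more compounds than this note shows. Statements on the series, on what has been measured and on what is new or still open speak of the compounds shown alone.

Compound 1 `N=C(S)CCCn1nc(-c2ccccc2)ccc1=O` is the reference point of this small set. In a functional assay on the whole organism (stomach) with Rattus norvegicus as the target (a lower number here means that less compound is needed, a higher number that more compound is needed for the effect), compound 1 gives 31.9 mg/kg, the lowest of the two numbers that exist for the series. Its nearest neighbour is compound 3 `N=C(S)CCn1nc(-c2ccccc2)ccc1=O`, which in this assay gives 87.3 mg/kg; the step of a 2.7-fold higher number from compound 1 to compound 3 (0.44 log units; beyond the scatter) shortens the chain by one saturated carbon. Compound 2 `N=C(S)CCCCCCn1nc(-c2ccccc2)ccc1=O` reaches only a limit in this assay, namely > 100 mg/kg (the limit of > 100 mg/kg in this assay, at which 1 of the 3 values shown sits). The step of an at least 3.1-fold higher number from compound 1 to compound 2 (0.49 log units; beyond the scatter) lengthens the same chain by three saturated carbons, and an at least 1.1-fold lower number from compound 2 to compound 3 (0.05 log units; that floor lies within the scatter) cannot be judged as more than its floor.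

Compound 4 `Cc1ccc(=O)n(CCCC(=N)S)n1` is not yet measured. It keeps the whole chain of compound 1 and alters the core instead: methyl in place of phenyl on an aromatic carbon. Among the measured compounds shown here, none of the measured steps touches this position; all three change the length of the chain that carries the thioamide, and each of them moved the number away from compound 1 rather than towards it. A change on the aromatic ring is therefore uncharted, and the estimate for compound 4 rests on compound 1 alone. Compound 4 is expected to give 65 mg/kg in this assay, within 25 mg/kg to 160 mg/kg, which amounts to an expected step of a 2.0-fold higher number from compound 1 to compound 4 (0.31 log units; beyond the scatter).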

Compound 4, dose for half-maximal effect: > 100 mg/kg
Compound 4: no number, only a limit (the forecaster's own chance of this, stated with the estimate: 30%); at least 1.5-fold (0.18 log units) between middle value and limit.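

In this assay, among the compounds shown here, methyl in place of phenyl on an aromatic carbon gives an at least 3.1-fold higher number from compound 1 to compound 4 (0.49 log units; beyond the scatter), which shows for the first time that the number responds to a change on the core of compound 1 and not only to the length of the chain carrying the thioamide. Compound 4 gives > 100 mg/kg, which is a limit of the assay and not a number, so this step has a floor but no known full size. With this result, the limit is no longer confined to a single compound in the series: the limit of > 100 mg/kg in this assay, at which 2 of the 4 values shown sit.

The compounds shown leave open whether another group at this position, such as benzyl, cyclohexyl or a phenyl carrying a methoxy group, would keep the number near that of compound 1, or would instead move it further in either direction. Also open, as far as these compounds go, is how the change from phenyl to methyl would read on a shorter or longer chain, as the methyl stands here only on the chain of compound 1.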